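The source may report more compounds than this note shows. Statements on the series, on what has been measured and on what is new or still open speak of the compounds shown alone.

Compound 1 `CCN1CCc2nc(C#Cc3ccccc3)sc2C1` gives 1200 nM in an assay on HEK293 cells for negative allosteric modulation of metabotropic glutamate receptor 5 (Homo sapiens), read by FLIPR, with a stated time of 1 h; on this read-out higher numbers stand for weaker inhibition and lower numbers for stronger inhibition.
Compound 2 `CCCCN1CCc2nc(C#Cc3ccccc3)sc2C1` gives > 10000 nM, which is a limit of this assay.
Compound 3 `CC1CC(C(=O)N2CCc3nc(C#Cc4ccccc4)sc3C2)C1` gives > 10000 nM, again a limit rather than a number.

Compound 3 therefore stands at the limit of > 10000 nM in this assay, at which 2 of the 3 values shown sit, with no number of its own. Compound 4 `O=C(c1cccc(Cl)c1)N1CCc2nc(C#Cc3ccccc3)sc2C1` differs from compound 3 in one place: 3-chlorophenyl in place of 3-methylcyclobutyl on a carbonyl carbon. Within the data shown here, no measured step changes the group on the carbonyl carbon. The step of an at least 8.3-fold higher number from compound 1 to compound 3 (0.92 log units; beyond the scatter) ends at the limit, and a step that the two limits leave unreadable from compound 2 to compound 3 cannot be read. Only the weak standing of compound 3 guides the expectation, so compound 4 is expected to stay weak, and the step of an at least 1.2-fold lower number from compound 3 to compound 4 (0.09 log units; that floor lies within the scatter) is estimated as little or none beyond the scatter. Compound 4 is expected near 8000 nM, within 2000 nM to 30000 nM, quite possibly again a limit.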

Compound 4, half-maximal inhibitory concentration: > 10000 nM
Compound 4 gave a limit, no number; the forecaster's own chance of this, stated with the estimate: 60%; middle value at least 1.2-fold (0.09 log units) from the limit.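

Compound 4 gives > 10000 nM, a limit and not a number; compound 3 also sits at a limit, so the step between them cannot be read. Still open, going by these compounds, is whether any group on the carbonyl carbon gives a readable number in this assay.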